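Methyl for Ethoxy on a Carbonyl Carbon

This account rests on a few compounds, and the source may have more. Where it says the series, first, only, none or still open, it means among the compounds named here.

In an ADME assay on L929 cells (Mus musculus) for cytotoxicity, read by resazurin assay, with a stated time of 48 h (on this read-out lower numbers stand for higher toxicity in this test and higher numbers for lower toxicity in this test), compound 2 (`CCOC(=O)n1c2ccc([N+](=O)[O-])cc2c(=O)n1Cc1ccccc1`) gives 122000 nM and compound 1 (`CCOC(=O)CCCn1c2ccc([N+](=O)[O-])cc2c(=O)n1Cc1ccccc1`) gives 78100 nM so the two cannot be told apart. Compound 3 (`CC(=O)n1c2ccc([N+](=O)[O-])cc2c(=O)n1Cc1ccccc1`) differs from compound 2 by methyl in place of ethoxy on a carbonyl carbon in one place, with methyl in place of ethoxy on a carbonyl carbon. Among the measured compounds shown here, the only measured step that bears on this is a 1.6-fold higher number from compound 1 to compound 2 (0.19 log units; within the scatter) and it also altered the group on the aromatic nitrogen. For the measured compounds named here, with that small step as the sole guide, no change beyond the scatter is expected, and the expected step is a 1.2-fold lower number from compound 2 to compound 3 (0.09 log units; within the scatter) on this evidence. In this assay compound 3 is estimated at 100000 nM with 45000 nM to 220000 nM as its expected range.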

Compound 3, concentration lethal to 50% of the cells: > 256000 nM
Compound 3: a limit, no number (the forecaster's own chance of this, stated with the estimate: 5%); middle value at least 2.5-fold (0.40 log units) from the limit.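

In this assay, methyl in place of ethoxy on a carbonyl carbon gives an at least 2.0-fold higher number from compound 2 to compound 3 (0.32 log units; beyond the scatter), so this position responds to the change, which the earlier pair, within the scatter, did not show. For compound 3, > 256000 nM is a limit of the assay and not a number. Acetyl in place of 3-(ethoxycarbonyl)propyl on an aromatic nitrogen likewise gives an at least 3.2-fold higher number from compound 1 to compound 3 (0.51 log units; beyond the scatter), again a step beyond the scatter.

On these data alone, how far compound 3 lies past its limit stays open. So does what an amine or a longer carbon chain on this carbonyl carbon would give.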